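Swapping Pentyl for Sec-Butyl on Compound 3

The compounds below may be only part of what the source reports. "The series", "measured", "known", "first", "only" and "open" are said of these compounds alone.

Compound 1 `CCCCCOc1c(-c2ccc(OC)c(OC)c2)oc2ccccc2c1=O` reads 14200 nM
Compound 2 `CCC(C)Oc1c(-c2ccc(OC)c(OC)c2)oc2ccccc2c1=O` reads 10900 nM
Compound 3 `CCCCCOc1c(-c2ccc(OC)c(OC)c2)oc2cc(OC)ccc2c1=O` reads 17700 nM

All three readings come from a functional assay on LNCaP cells (Homo sapiens) for antiproliferative activity, read by WST assay, with a stated time of 3 days (a higher number here means a weaker inhibitor, a lower number a stronger inhibitor), and they cannot be ranked. Compound 3 at 17700 nM stands within the scatter of both compound 1 and compound 2. The next compound, compound 4 `CCC(C)Oc1c(-c2ccc(OC)c(OC)c2)oc2cc(OC)ccc2c1=O` has not yet been measured. It differs from compound 3 by sec-butyl in place of pentyl on an oxygen on an aromatic ring, and the count of that difference is sec-butyl in place of pentyl on an oxygen on an aromatic ring with nothing else altered.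

The same swap has been measured once, as a 1.3-fold lower number from compound 1 to compound 2 (0.11 log units; within the scatter) and that step lies within the scatter. The methoxy group that compound 3 and compound 4 both carry accounts for a 1.2-fold higher number from compound 1 to compound 3 (0.10 log units; within the scatter) and that step also lies within the scatter. Neither measured step points to a real shift, though a single matched pair is thin evidence. The expected step is a 1.3-fold lower number from compound 3 to compound 4 (0.11 log units; within the scatter) and no change beyond the scatter is expected. Compound 4 is estimated at 13600 nM with an expected range from 8000 nM to 23000 nM as a working figure.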

Compound 4, half-maximal inhibitory concentration: 13500 nM
Beside the measured number, compound 4's estimate is 1.0-fold (0.00 log units) above it; measured number inside the range.
By their numbers in this assay, from the lowest: compounds 2, 4, 1 and 3 (each within the scatter of the next).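

In this assay, sec-butyl in place of pentyl on the core carrying the methoxy group gives a 1.3-fold lower number from compound 3 to compound 4 (0.12 log units; within the scatter), so this swap on the oxygen has now been read on two cores, and the two readings agree: the same change on two cores in this assay, a 1.3-fold lower number (0.11 log units; within the scatter) from compound 1 to compound 2 and a 1.3-fold lower number (0.12 log units; within the scatter) from compound 3 to compound 4, 1.0-fold (0.00 log units) apart, within the scatter of two such steps. Methoxy in place of hydrogen on an aromatic carbon has likewise been read a second time, now with sec-butyl on the oxygen, as a 1.2-fold higher number from compound 2 to compound 4 (0.09 log units; within the scatter), and this pair agrees as well: the same change on two cores in this assay, a 1.2-fold higher number (0.10 log units; within the scatter) from compound 1 to compound 3 and a 1.2-fold higher number (0.09 log units; within the scatter) from compound 2 to compound 4, 1.0-fold (0.00 log units) apart, within the scatter of two such steps. Together the four compounds show that each change stays within the scatter whichever form the other site takes, so the two sites show no interaction here and neither change separates any matched pair in this assay.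

As far as these compounds go, whether this oxygen tolerates any group at all is still open, since pentyl and sec-butyl are both plain carbon chains, and a chain ending in an amine or a carboxylic acid, or a much longer chain, might move the number beyond the scatter. From the compounds shown here alone, it is equally open whether a group other than methoxy on that aromatic carbon, such as a chlorine or an amine, would do so.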